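Swapping a Quinoline for a Benzothiophene on the Amide

The compounds below may be only part of what the source reports. "The series", "measured", "known", "first", "only" and "open" are said of these compounds alone.

Measured so far:
compound 1 `CCc1ccc(C(=O)NC[C@H]2c3[nH]c4ccccc4c3C[C@H]3[C@H]4c5[nH]c6ccccc6c5C[C@@H]([C@H](C#N)N23)N4C)cc1` gives 670 nM
compound 2 `CN1[C@@H]2c3[nH]c4ccccc4c3C[C@H]1[C@H](C#N)N1[C@@H](CNC(=O)c3cccc4c3CCCC4)c3[nH]c4ccccc4c3C[C@@H]21` gives 810 nM
compound 3 `CN1[C@@H]2c3[nH]c4ccccc4c3C[C@H]1[C@H](C#N)N1[C@@H](CNC(=O)c3ccc4ccccc4n3)c3[nH]c4ccccc4c3C[C@@H]21` gives 60 nM

In a functional assay on A2780 cells (Homo sapiens) for cytotoxicity, read by MTT assay, with a stated time of 72 h (on this read-out lower numbers stand for stronger inhibition and higher numbers for weaker inhibition), compound 3 stands lowest of the three; its nearest neighbour is an 11-fold lower number from compound 1 to compound 3 (1.05 log units; beyond the scatter) and the furthest is a 14-fold lower number from compound 2 to compound 3 (1.13 log units; beyond the scatter). Compound 4 `CN1[C@@H]2c3[nH]c4ccccc4c3C[C@H]1[C@H](C#N)N1[C@@H](CNC(=O)c3cc4ccccc4s3)c3[nH]c4ccccc4c3C[C@@H]21` differs from compound 3 by one change: 1-benzothiophen-2-yl in place of quinolin-2-yl on a carbonyl carbon. For the measured compounds named here, the steps that bear on this are those into compound 3: an 11-fold lower number from compound 1 to compound 3 (1.05 log units; beyond the scatter) and a 14-fold lower number from compound 2 to compound 3 (1.13 log units; beyond the scatter), both large and both leading from an all-carbon aromatic group to the quinoline. The new group is again bicyclic and aromatic but keeps only one hetero atom, in a five-membered ring. A step back toward the weaker numbers is therefore expected, likely smaller than those two: a 3.3-fold higher number from compound 3 to compound 4 (0.52 log units; beyond the scatter). Compound 4 is estimated at 200 nM, in the range 60 nM to 700 nM.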

Compound 4, half-maximal inhibitory concentration: 20 nM
Beside the measured number, compound 4's estimate is 10-fold (1.00 log units) above it; the whole stated range lies above it.
By their numbers in this assay, from the lowest: compound 4; then compound 3; then compounds 1 and 2 (each within the scatter of the next).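

In this assay, a group without the quinoline nitrogen can reach lower numbers: 1-benzothiophen-2-yl in place of quinolin-2-yl gives a 3.0-fold lower number from compound 3 to compound 4 (0.48 log units; beyond the scatter) on this carbonyl carbon. The same group gives a 41-fold lower number from compound 2 to compound 4 (1.61 log units; beyond the scatter) and a 34-fold lower number from compound 1 to compound 4 (1.53 log units; beyond the scatter) from the two groups that lack a hetero atom, so the large drops at this position do not depend on a ring nitrogen. No measurement at hand explains these drops. Still open, going by these compounds, is how a benzofuran-2-yl or indol-2-yl group, with oxygen or nitrogen in place of the sulfur, would compare, and what a carboxylic acid or an amine added to the benzothiophene would do.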